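The source may hold more compounds than are shown below. What is called first, only, known or untested is meant among the compounds shown, and "the series" means these compounds.

Compound 1 `COc1ccc(CNC(=O)c2cc3cc(OC)c(OCCCOc4no[n+]([O-])c4S(=O)(=O)c4ccccc4)cc3oc2=O)cc1`: in a functional assay on MDA-MB-231 cells (Homo sapiens) for inhibition, read by MTT assay, with a stated time of 48 h (on this read-out lower numbers stand for stronger inhibition and higher numbers for weaker inhibition), compound 1 gives 780 nM.
Compound 2 `COc1cc2cc(C(=O)NCCCc3ccccc3)c(=O)oc2cc1OCCCOc1no[n+]([O-])c1S(=O)(=O)c1ccccc1`: in this assay compound 2 gives 760 nM.
Compound 3 `COc1ccc(NC(=O)c2cc3cc(OC)c(OCCCOc4no[n+]([O-])c4S(=O)(=O)c4ccccc4)cc3oc2=O)cc1`: in this assay compound 3 gives 730 nM.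

All three compounds share one core and differ only in the group carried on the amide-type nitrogen. The steps between them are small: a 1.0-fold lower number from compound 1 to compound 2 (0.01 log units; within the scatter), a 1.1-fold lower number from compound 1 to compound 3 (0.03 log units; within the scatter) and a 1.0-fold lower number from compound 2 to compound 3 (0.02 log units; within the scatter). Compound 3 therefore holds the lowest of the three numbers, but its two neighbours sit within the usual scatter, so no ranking among them can be drawn.

Compound 4 `COc1cc2cc(N)c(=O)oc2cc1OCCCOc1no[n+]([O-])c1S(=O)(=O)c1ccccc1` goes further: amino in place of (4-methoxyphenyl)carbamoyl on an aromatic carbon. For the measured compounds named here, the measured steps only exchanged the group on the amide-type nitrogen and left the carbonyl in place, and none of them moved the number beyond the scatter; no measured step removes the whole carbamoyl unit. Those steps suggest that this side of the molecule tolerates change, yet a cut this deep goes beyond what they cover, so a modest rise in the number is expected, a 2.1-fold higher number from compound 3 to compound 4 (0.31 log units; beyond the scatter). For compound 4 the estimate in this assay is 1500 nM, with a range from 500 nM to 6000 nM.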

Compound 4, half-maximal inhibitory concentration: 1390 nM
The estimate for compound 4 lay 1.1-fold (0.03 log units) above the measured number; measured number inside the range.
By their numbers in this assay, from the lowest: compounds 3, 2, 1 and 4 (each within the scatter of the next).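

Replacing the whole carbamoyl unit with a bare amino group on this aromatic carbon leaves every step within the usual scatter in this assay, with a 1.9-fold higher number from compound 3 to compound 4 (0.28 log units; within the scatter) and a 1.8-fold higher number from compound 2 to compound 4 (0.26 log units; within the scatter) and a 1.8-fold higher number from compound 1 to compound 4 (0.25 log units; within the scatter). The earlier steps shown here only exchanged the group on the amide-type nitrogen, whereas these show that, across the four compounds, neither the carbonyl nor the aromatic ring of the departing groups is required for a number in this range. No measurement here accounts for this tolerance.

On these data alone, what a carboxylic acid or a simple acetamide would give on this same aromatic carbon stays open. So does the effect of a longer chain in the ether linkage of the shared core, which all four compounds keep unchanged.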